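Triazole aryl swaps on the shared core, cytotoxicity notes

This account rests on a few compounds, and the source may have more. Where it says the series, first, only, none or still open, it means among the compounds named here.

Two numbers are known in a functional assay on HeLa cells (Homo sapiens) for cytotoxicity, read by MTT assay, with a stated time of 72 h; a higher number here means that more compound is needed for the effect, a lower number that less compound is needed. Among the measured compounds shown here, compound 1 `CCS[C@@H]1[C@H](SCC)[C@@H](Cn2cc(-c3ccc(F)cc3)nn2)O[C@H]1n1ccc(=O)[nH]c1=O` gives 37400 nM, and compound 2 `CCS[C@@H]1[C@H](SCC)[C@@H](Cn2cc(-c3ccccc3C(F)(F)F)nn2)O[C@H]1n1ccc(=O)[nH]c1=O` gives 32800 nM; the only measured step, a 1.1-fold lower number from compound 1 to compound 2 (0.06 log units; within the scatter), leaves the two within the scatter of each other. Compound 3 `CCS[C@@H]1[C@H](SCC)[C@@H](Cn2cc(-c3cccc(C)c3)nn2)O[C@H]1n1ccc(=O)[nH]c1=O` carries the change (3-methylphenyl in place of 4-fluorophenyl on an aromatic carbon). For the measured compounds named here, the single step that bears on this aryl position, from compound 1 to compound 2, was flat, so no movement beyond the scatter is expected in this assay, in either direction. The expected step is therefore a 1.1-fold lower number from compound 1 to compound 3 (0.03 log units; within the scatter). Compound 3 is estimated at 35000 nM, with a range from 15000 nM to 80000 nM.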

Compound 3, half-maximal effective concentration: 18800 nM
Beside the measured number, compound 3's estimate is 1.9-fold (0.27 log units) above it; the measured number falls inside the stated range.
By their numbers in this assay, from the lowest: compounds 3, 2 and 1 (each within the scatter of the next).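

At this aryl position in this assay, 3-methylphenyl, which carries no fluorine, stays level with both fluorinated aryl groups: a 2.0-fold lower number from compound 1 to compound 3 (0.30 log units; within the scatter), and a 1.7-fold lower number from compound 2 to compound 3 (0.24 log units; within the scatter). The flat reading therefore now spans three aryl groups with different substituents, though the step from 4-fluorophenyl lies at the edge of the scatter. Nothing available explains these numbers. Still open, on these data alone, is whether an amine or a carboxylic acid on the phenyl ring would give a step beyond the scatter. The same question stands for a longer alkyl chain in place of the aryl group.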